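Sigma-1 binding: naphthyl replacing methoxyphenyl on a thiophene core

This account rests on a few compounds, and the source may have more. Where it says the series, first, only, none or still open, it means among the compounds named here.

Of the compounds shown here, two have been measured in an assay on membranes from brain for displacement of a labelled ligand from Sigma non-opioid intracellular receptor 1 (Cavia porcellus), read by scintillation counting, with a stated time of 120 min; a lower number here means a stronger inhibitor, a higher number a weaker inhibitor. Compound 1 `N#Cc1ccc(-c2scc3c2CCOC32CCN(Cc3ccccc3)CC2)cc1` gives 3.4 nM. Compound 2 `COc1ccc(-c2cc3c(s2)C2(CCN(Cc4ccccc4)CC2)OC(OC)C3)cc1` gives 56 nM, the higher of the two numbers, with compound 1 beyond the scatter below it. Compound 3 `COC1Cc2cc(-c3cccc4ccccc34)sc2C2(CCN(Cc3ccccc3)CC2)O1` keeps the core of compound 2 and changes one group: naphthalen-1-yl in place of 4-methoxyphenyl on an aromatic carbon. For the measured compounds named here, no measured pair shows this kind of swap, so its size is open. For compound 3 the expected value is 25 nM, between 8 nM and 80 nM. That estimate means a modest step of a 2.2-fold lower number from compound 2 to compound 3 (0.35 log units; beyond the scatter), possibly within the scatter.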

Compound 3, inhibition constant: 12 nM
Compound 3: middle estimate off by 2.1-fold (0.32 log units), on the high side, and the stated range covers the measured number.
By their numbers in this assay, from the lowest: compound 1; then compound 3; then compound 2.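

Putting naphthalen-1-yl in place of 4-methoxyphenyl on the aromatic carbon next to the ring sulfur gives a 4.7-fold lower number from compound 2 to compound 3 (0.67 log units; beyond the scatter). This position therefore tolerates a second aromatic ring, and the hydrogen-bond acceptor of 4-methoxyphenyl is not needed for a number in this range. No measurement here bears on why the number falls.

The swap adds a ring and removes the methoxy group in one step, so their separate contributions remain unresolved. An unsubstituted phenyl or a naphthalen-2-yl at this carbon would help separate them.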